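Thiophen-2-yl in Place of Furan-3-yl: a Repeated Small Step

A few compounds are considered here, and "the series" means these few. Any claim that something is new, unique, unknown or untested is made for them only; others in the source may bear on it.

Measured so far:
compound 1, `COC(=O)C1=C(C)N(C)C(=O)NC1c1ccoc1`: 7%
compound 2, `COC(=O)C1=C(C)N(C)C(=O)NC1c1cccs1`: 17%
compound 3, `CCNC(=O)C1=C(C)NC(=O)NC1c1ccoc1`: 2%

All three compounds share a six-membered non-aromatic ring with 2 nitrogen and were tested in an assay on membranes from HEK293 cells for displacement of a labelled ligand from adenosine receptor A2b (Homo sapiens), read by scintillation counting, with a stated time of 30 min, tested at 1 uM; on this read-out higher numbers stand for more inhibition at the one concentration tested (going by the name of the read-out) and lower numbers for less inhibition. Compound 1 and compound 2 differ only in the group on a saturated ring carbon: thiophen-2-yl in place of furan-3-yl on a saturated ring carbon. That change gave a number 10 percentage points higher from compound 1 to compound 2 (within the scatter). Compound 3 also carries the furan-3-yl group, but its core differs from that of compound 1 in more than one place; the difference between the two cores is not broken down here. Compound 3 sits apart from compound 2 by a gap beyond the scatter, while its gap to compound 1 lies within the scatter.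

Compound 4, `CCNC(=O)C1=C(C)NC(=O)NC1c1cccs1`, has not yet been measured. It comes from compound 3 by the same kind of change, (thiophen-2-yl in place of furan-3-yl on a saturated ring carbon). The surroundings differ: in compound 3 the saturated ring carbon is next to the ring atom that bears an ethylcarbamoyl group, whereas in compound 1 it is next to the ring atom that bears a methoxycarbonyl group. Because the earlier step of a number 10 percentage points higher from compound 1 to compound 2 (within the scatter) stayed within the scatter, only a small step is expected from compound 3 to compound 4, a number 10 percentage points higher from compound 3 to compound 4 (within the scatter). Compound 4 is therefore estimated to give about 12%, expected between -5% and 30%.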

Compound 4, a percentage reported as inhibition, at one concentration (the size of the read-out at that concentration, not a potency): 1%
For compound 4 the middle estimate is 11 percentage points above the measured one, within the range that was stated.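

In this assay, among the compounds shown here, placing thiophen-2-yl where furan-3-yl stood on the core of compound 3 gave a number 1 percentage points lower from compound 3 to compound 4 (within the scatter), so on this second core the change again produced no step that can be told apart from ordinary repeat-to-repeat variation. The two steps also agree within what repeated measurements would allow: the same change on two cores in this assay, a number 10 percentage points higher (within the scatter) from compound 1 to compound 2 and a number 1 percentage points lower (within the scatter) from compound 3 to compound 4, 11 percentage points apart, within the scatter of two such steps. This shows that, on these two cores, the change carried over as a small step, but it does not show that the change has no effect on binding, as each number comes from a single concentration and stays low, and two cores are too few to support a rule for the series.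

The cores of compound 1 and compound 3 differ in more than one place, so the compounds shown cannot say which difference, if any, matters for this read-out. They also leave open whether the step stays small on a core carrying a carboxylic acid or a longer chain in place of the ethylcarbamoyl group.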